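This account rests on a few compounds, and the source may have more. Where it says the series, first, only, none or still open, it means among the compounds named here.

Measured so far in an assay on HEK293 cells for inhibition of protein deacetylase HDAC6 (Homo sapiens); a lower number here means a stronger inhibitor, a higher number a weaker inhibitor:
compound 1 `CCOC(=O)SCC(=O)c1ccc(OC)cc1` gives 5360 nM;
compound 2 `CCNC(=O)SCC(=O)c1ccc(OC)cc1` gives 132 nM;
compound 3 `CCNC(=S)SCC(=O)c1ccc(OC)cc1` gives 94 nM.

Compound 4 `CCOC(=S)SCC(=O)c1ccc(OC)cc1` has not yet been measured in this assay. It differs from compound 3 in one place: ethoxy in place of ethylamino on a thiocarbonyl carbon. The same change occurs once more among these compounds, between compound 2 and compound 1: ethoxy in place of ethylamino on a carbonyl carbon. That step gave a 41-fold higher number from compound 2 to compound 1 (1.61 log units; beyond the scatter). The two cores are not identical, though: compound 3 differs from compound 2 by a group of 5 heavy atoms (3 carbon, 1 nitrogen, 1 sulfur; no ring) in place of a group of 5 heavy atoms (3 carbon, 1 nitrogen, 1 oxygen; no ring), on a sulfur, a step of a 1.4-fold lower number from compound 2 to compound 3 (0.15 log units; within the scatter). So the change in compound 3 sits on a thiocarbonyl carbon whose other neighbours are sulfur, while in compound 2 it sits on a carbonyl carbon whose other neighbours are sulfur; this is the same kind of change, not the same change. Compound 1 against compound 3 shows a 57-fold lower number from compound 1 to compound 3 (1.76 log units; beyond the scatter). Because the earlier step of a 41-fold higher number from compound 2 to compound 1 (1.61 log units; beyond the scatter) was large, a step of similar size is expected for compound 4: a 37-fold higher number from compound 3 to compound 4 (1.57 log units; beyond the scatter). Compound 4 is therefore estimated at 3500 nM, likely between 1000 nM and 12000 nM.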

Compound 4, half-maximal inhibitory concentration: 448 nM
Estimate against measurement, compound 4: 7.8-fold (0.89 log units) above; the whole stated range lies above it.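

In this assay, ethoxy in place of ethylamino on a thiocarbonyl carbon gives a 4.8-fold higher number from compound 3 to compound 4 (0.68 log units; beyond the scatter), the same direction as on the carbonyl carbon but a clearly smaller step, so the direction carried from one core to the other while the size did not: the same change on two cores in this assay, a 41-fold higher number (1.61 log units; beyond the scatter) from compound 2 to compound 1 and a 4.8-fold higher number (0.68 log units; beyond the scatter) from compound 3 to compound 4, 8.5-fold (0.93 log units) apart, beyond the scatter of two such steps. The ethoxy compounds also respond differently to the carbonyl-to-thiocarbonyl exchange, which gives a 12-fold lower number from compound 1 to compound 4 (1.08 log units; beyond the scatter), whereas among the ethylamino compounds it gives only a 1.4-fold lower number from compound 2 to compound 3 (0.15 log units; within the scatter), and the ethoxy thiocarbonyl still ends with a 3.4-fold higher number from compound 2 to compound 4 (0.53 log units; beyond the scatter) against the ethylamino carbonyl. These two pairs do not explain why the steps differ, and they cannot fix the size of this change on any third core.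

The compounds shown leave open how other groups on the same carbon would behave, such as a methylamino, a dimethylamino or a longer chain like propylamino. They also leave open whether a methoxy or a propoxy would follow the ethoxy compounds.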